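The source may report more compounds than this note shows. Statements on the series, on what has been measured and on what is new or still open speak of the compounds shown alone.

Three compounds share one core and differ only in the aryl group attached to the ring amine nitrogen. Compound 1 `Nc1scc(CN2CCN(c3ccc(Cl)cc3F)CC2)c1C(=O)c1ccc(Cl)cc1` gives -9.4% in a functional assay on CHO cells with adenosine receptor A1 (Homo sapiens) as the target, read by cAMP accumulation and immunoassay, with a stated time of 6 min, tested at 0.1 uM; on this read-out higher numbers stand for a weaker effect at the one concentration tested and lower numbers for a stronger effect. Compound 2 `Nc1scc(CN2CCN(c3ccc(OC(F)(F)F)cc3)CC2)c1C(=O)c1ccc(Cl)cc1` gives -13%, and compound 3 `Nc1scc(CN2CCN(c3c(F)cccc3F)CC2)c1C(=O)c1ccc(Cl)cc1` gives -23%. Compound 3 stands apart from compound 1 by a number 13.6 percentage points lower from compound 1 to compound 3 (beyond the scatter), but from compound 2 only by a number 10 percentage points lower from compound 2 to compound 3 (within the scatter), so compounds 2 and 3 cannot be told apart here. Compound 4 `Nc1scc(CN2CCN(c3cc(F)ccc3F)CC2)c1C(=O)c1ccc(Cl)cc1` is not yet measured; it differs from compound 3 by 2,5-difluorophenyl in place of 2,6-difluorophenyl on an amine nitrogen in a ring. Within the data shown here, no measured step swaps one difluorophenyl pattern for another, and all three measured steps, including a number 3.6 percentage points lower from compound 1 to compound 2 (within the scatter), were small, so the expected step of a number 7 percentage points higher from compound 3 to compound 4 (within the scatter) is none beyond the scatter. Compound 4 is therefore expected to give about -16%, somewhere between -32% and 0%.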

Compound 4, a percentage reported as activity, at one concentration (the size of the read-out at that concentration, not a potency): -13%
For compound 4 the middle estimate is 3 percentage points below the measured one; the measured number falls inside the stated range.
By their numbers in this assay, from the lowest: compounds 3, 2, 4 and 1 (each within the scatter of the next, the first and the last beyond it).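

This is the only step shown that swaps one difluorophenyl pattern for another on an amine nitrogen in a ring, and in this assay it gives a number 10 percentage points higher from compound 3 to compound 4 (within the scatter). The other two comparisons give no change at the digits printed from compound 2 to compound 4 (within the scatter) and a number 3.6 percentage points lower from compound 1 to compound 4 (within the scatter), so compound 4 cannot be told apart from any earlier compound, although compound 1 and compound 3 can be told apart from each other. Nothing available explains these results. Still open, from the compounds shown here alone, is whether a methyl group on this nitrogen, or a phenyl ring carrying a carboxylic acid, would stand clearly apart from these four compounds. Readings at a single concentration also leave their potencies open.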